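Replacing methoxy with cyano on compound 2

This account rests on a few compounds, and the source may have more. Where it says the series, first, only, none or still open, it means among the compounds named here.

Compound 1 `COc1ccc(S(=O)(=O)Nc2cccc3cc[nH]c23)cc1`: 1.1 ug/mL
Compound 2 `COc1ccc(S(=O)(=O)Nc2ccc(Cl)c3cc[nH]c23)cc1`: 1.1 ug/mL
Compound 3 `Cc1ccc(S(=O)(=O)Nc2cccc3cc(Cl)[nH]c23)cc1`: 0.14 ug/mL

All three were measured in a functional assay on P388 cells (Mus musculus) for antiproliferative activity, read by colorimetric assay and MTT assay; on this read-out lower numbers stand for stronger inhibition and higher numbers for weaker inhibition. Compound 2 stands level with compound 1, and compound 3 alone sits lower, at 0.14 ug/mL. Compound 4 `N#Cc1ccc(S(=O)(=O)Nc2ccc(Cl)c3cc[nH]c23)cc1` has cyano in place of methoxy on an aromatic carbon. For the measured compounds named here, the only measured step, no change at the digits printed from compound 1 to compound 2 (within the scatter), is a different exchange, chloro in place of hydrogen, so it gives no direct size for this one. Going by the values given here, no measured step covers this exchange, so no step beyond the scatter is expected in this assay, and the direction stays open. The expected change is a 1.4-fold lower number from compound 2 to compound 4 (0.14 log units; within the scatter). For compound 4 the estimated value is 0.8 ug/mL, with an expected range of 0.2 ug/mL to 2.5 ug/mL.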

Compound 4, half-maximal inhibitory concentration: 1.8 ug/mL
Estimate against measurement, compound 4: 2.3-fold (0.35 log units) below; low and high end bracket the measured number.
By their numbers in this assay, from the lowest: compound 3; then compounds 1, 2 and 4 (each within the scatter of the next).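

In this assay cyano in place of methoxy, on an aromatic carbon para to a large group, gives a 1.6-fold higher number from compound 2 to compound 4 (0.21 log units; within the scatter) and thus no step beyond the scatter. For the compounds shown here, this is the first exchange measured at this place, which the earlier compounds left untouched. With the rest of compound 2 held fixed, methoxy can give way to cyano without a clear shift in antiproliferative activity. On these data alone, whether an amine or a carboxylic acid at this place would move the number beyond the scatter stays open. No measurement at hand accounts for this result.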